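Working notes: swapping the aniline group on the shared core

The source may report more compounds than this note shows. Statements on the series, on what has been measured and on what is new or still open speak of the compounds shown alone.

compound 1 `CCCc1ccc(NC2=CC(=O)c3nc4n(c3C2=O)[C@H]2OC[C@@H](O)[C@H]2OC4)cc1` — 4660 nM
compound 2 `O=C1C(Nc2ccc(Br)cc2)=CC(=O)c2c1nc1n2[C@H]2OC[C@@H](O)[C@H]2OC1` — 4330 nM

In a functional assay on MCF7 cells (Homo sapiens) for inhibition, read by sulforhodamine B assay (on this read-out lower numbers stand for stronger inhibition and higher numbers for weaker inhibition), compound 1 gives 4660 nM, a number that cannot be told apart from that of compound 2, at 4330 nM, given the usual scatter. Compound 1 therefore holds no separate place among the two measured compounds.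

Compound 3 `O=C1C=C(Nc2ccccc2F)C(=O)c2c1nc1n2[C@H]2OC[C@@H](O)[C@H]2OC1` has not yet been measured. It carries 2-fluorophenyl in place of 4-propylphenyl on an amine nitrogen. For the measured compounds named here, no measured pair isolates this change, so the data give no direction for it. In this assay no shift beyond the scatter is expected, and the starting point is compound 1 at 4660 nM. The estimated step is a 1.0-fold lower number from compound 1 to compound 3 (0.02 log units; within the scatter). For compound 3 the expected value is 4500 nM, with an estimated range of 1800 nM to 11000 nM.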

Compound 3, half-maximal inhibitory concentration: 3640 nM
Estimate against measurement, compound 3: 1.2-fold (0.09 log units) above; the measured number falls inside the stated range.
By their numbers in this assay, from the lowest: compounds 3, 2 and 1 (each within the scatter of the next).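

In this assay, for the compounds shown here, the first pair to isolate a change on this amine nitrogen gives a 1.3-fold lower number from compound 1 to compound 3 (0.11 log units; within the scatter) with 2-fluorophenyl in place of 4-propylphenyl. The group on this nitrogen can therefore go from 9 heavy atoms, all carbon, to 7 heavy atoms including a fluorine, with a step that stays within the scatter. No available measurement bears on this result.

As far as these compounds go, the effect of a non-aromatic group such as cyclohexyl on this nitrogen, or of a phenyl ring carrying a carboxylic acid or an amine, stays open. It is also open whether the absence of a step beyond the scatter holds for groups outside the three substituted phenyl rings shown here.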